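Ester to Acid on a Tetrazole Ether Scaffold

A few compounds are considered here, and "the series" means these few. Any claim that something is new, unique, unknown or untested is made for them only; others in the source may bear on it.

Measured so far:
- compound 1, `CC(Oc1ccc(Oc2ccc(F)cc2)cc1)C(=O)Cn1nnc(-c2ccccc2)n1`: in an ADME assay on S9 fraction from liver (Rattus norvegicus) for metabolic stability, read by LC-MS, using NADPH, with a stated time of 30 min (on this read-out higher numbers stand for a more stable compound and lower numbers for a less stable compound), compound 1 gives < 5%, which is a limit of the assay, not a number.
- compound 2, `COC(=O)c1ccc(-c2nnn(CC(=O)C(C)Oc3ccc(Oc4ccc(F)cc4)cc3)n2)cc1`: in this assay compound 2 gives < 5%, again a limit rather than a number.

Compound 2 therefore stands at the floor of what this assay can report. Compound 3, `CC(Oc1ccc(Oc2ccc(F)cc2)cc1)C(=O)Cn1nnc(-c2ccc(C(=O)O)cc2)n1`, differs from compound 2 by hydrogen in place of methyl on an oxygen next to a carbonyl group. Among the measured compounds shown here, only one measured step exists: a step that the two limits leave unreadable from compound 1 to compound 2. For the measured compounds named here, its size cannot be read because of the limit of < 5% in this assay, at which 2 of the 2 values shown sit, so no measured step gives a direction or a size for the change to compound 3. Without any readable step, the expectation for compound 3 in this assay rests on the observation that both measured values sit at the limit, and the estimated step of a number at least 15 percentage points higher from compound 2 to compound 3 (beyond the scatter) is set accordingly. Compound 3 is expected to give about 20%, within 3% to 60%.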

Compound 3, percent of the compound remaining: 33%
For compound 3 the middle estimate is 13 percentage points below the measured one; measured number inside the range.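

With the carboxy group in place, the series gives its first read-out in this assay that is a number and not a limit. Hydrogen in place of methyl on an oxygen next to a carbonyl group gives a number at least 28 percentage points higher from compound 2 to compound 3 (beyond the scatter), and carboxy in place of hydrogen on an aromatic carbon gives a number at least 28 percentage points higher from compound 1 to compound 3 (beyond the scatter). So the free carboxy group separates from both the methoxycarbonyl group and plain hydrogen at this position, but each step is known only as a lower bound because its starting value is a limit: the limit of < 5% in this assay, at which 2 of the 3 values shown sit.

From the compounds shown here alone, how a primary amide or a hydroxymethyl group at the same position would read in this assay remains open. Also open, going by these compounds, is whether the carboxy group would give a similar step on a core with a longer chain.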